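Cyano in Place of Chloro: An Open Step

This account rests on a few compounds, and the source may have more. Where it says the series, first, only, none or still open, it means among the compounds named here.

Three compounds have been measured so far in a functional assay on HUVEC cells (Homo sapiens) for inhibition, with a stated time of 4 days; on this read-out lower numbers stand for stronger inhibition and higher numbers for weaker inhibition:
compound 1 `COc1ccc(C(N)=O)cc1/C=C/c1ccccc1` gives 2400 nM
compound 2 `COc1ccc(C(N)=O)cc1/C=C/c1cccc(C)c1` gives 3900 nM
compound 3 `COc1ccc(C(N)=O)cc1/C=C/c1cccc(Cl)c1` gives 24000 nM

Compound 3 has the highest number of the three, and so the weakest inhibition in this assay. The data show a 6.2-fold higher number from compound 2 to compound 3 (0.79 log units; beyond the scatter) and also a 10-fold higher number from compound 1 to compound 3 (1.00 log units; beyond the scatter) on this read-out.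

Compound 4 `COc1ccc(C(N)=O)cc1/C=C/c1cccc(C#N)c1` has not yet been measured. It carries cyano in place of chloro on an aromatic carbon, meta to a large group (cyano in place of chloro on an aromatic carbon).

Going by the values given here, no measured step brings in cyano, so the evidence is indirect. Putting methyl on this carbon gave a 1.6-fold higher number from compound 1 to compound 2 (0.21 log units; within the scatter), whereas chloro gave the larger step already shown from compound 1. From the compounds shown here alone, compound 3 therefore stands apart from the other two, and the loss of chloro leads to an expected drop in the number, though the effect of cyano itself remains untested. The expected change is a 3.0-fold lower number from compound 3 to compound 4 (0.48 log units; beyond the scatter) in this estimate. The estimate for compound 4 is 8000 nM with an expected range from 2500 nM to 25000 nM as its limits.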

Compound 4, half-maximal inhibitory concentration: 49000 nM
The estimate for compound 4 lay 6.1-fold (0.79 log units) below the measured number, outside the stated range (above it).
By their numbers in this assay, from the lowest: compounds 1 and 2 (each within the scatter of the next); then compound 3; then compound 4.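

In this assay this aromatic carbon tolerates cyano no better than chloro, with a 2.0-fold higher number from compound 3 to compound 4 (0.31 log units; beyond the scatter) and no return towards the lower numbers. The high number at this position therefore no longer belongs to chloro alone, for cyano also sets itself apart from hydrogen and methyl, with a 13-fold higher number from compound 2 to compound 4 (1.10 log units; beyond the scatter) and a 20-fold higher number from compound 1 to compound 4 (1.31 log units; beyond the scatter) as the two largest steps seen at this carbon so far. Cyano brings in a triple bond and a hydrogen-bond acceptor that chloro does not have, but nothing in the data connects the higher number with either feature or offers any explanation for this step.

What the four compounds leave open is whether any group other than methyl can sit on this carbon without a clear rise in the number, and whether fluoro or methoxy would fall with methyl or with chloro and cyano. From the compounds shown here alone, it is equally open whether an amine or a carboxylic acid here would keep the number near those of compound 1 and compound 2 or push it higher still.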